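The source may report more compounds than this note shows. Statements on the series, on what has been measured and on what is new or still open speak of the compounds shown alone.

Measured compounds in this series:
compound 1 `O=c1c(-c2ccc(O)cc2)coc2cc(OC(F)F)cc(O)c12`: 4.59 uM
compound 2 `CC(=O)Oc1ccc(-c2coc3cc(OC(C)=O)cc(O)c3c2=O)cc1`: 11.2 uM
compound 3 `CCCCCCCCOc1ccc(-c2coc3cc(OC(F)F)cc(OCCCCCCCC)c3c2=O)cc1`: 1.64 uM

In a functional assay on SGC-7901 cells (Homo sapiens) for inhibition, read by MTT assay (on this read-out higher numbers stand for weaker inhibition of growth and lower numbers for stronger inhibition of growth), compound 2 gives the highest of the three numbers; compound 1 is nearest and compound 3 furthest, both gaps beyond the scatter. Compound 4 `CC(=O)Oc1cc(O)c2c(=O)c(-c3ccc(O)cc3)coc2c1` has not been measured. It differs from compound 2 in one place: hydrogen in place of acetyl on an oxygen on an aromatic ring. Going by the values given here, no two measured compounds differ in a single place, so no measured step guides this change. Since compound 1, which also carries hydroxy rather than acetoxy, gives 4.59 uM, a move toward stronger inhibition is expected. The expected step is a 1.5-fold lower number from compound 2 to compound 4 (0.17 log units; within the scatter), probably within the scatter. For compound 4 the estimate is 7.5 uM, with a range from 3.2 uM to 18 uM.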

Compound 4, concentration for growth inhibition (reported as GI): 8.11 uM
Beside the measured number, compound 4's estimate is 1.1-fold (0.03 log units) below it; low and high end bracket the measured number.
By their numbers in this assay, from the lowest: compound 3; then compounds 1, 4 and 2 (each within the scatter of the next, the first and the last beyond it).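

In this assay, the first single-place comparisons both fall within the scatter: a 1.4-fold lower number from compound 2 to compound 4 (0.14 log units; within the scatter) for hydrogen in place of acetyl, and a 1.8-fold higher number from compound 1 to compound 4 (0.25 log units; within the scatter) for acetyl in place of difluoromethyl, each on an oxygen on an aromatic ring. On this read-out, neither exchange separates the compounds. No evidence is available to explain this result.

On these data alone, it remains open whether a group such as an aminoethyl chain or a carboxylic acid on this oxygen would move the number beyond the scatter.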